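The source may report more compounds than this note shows. Statements on the series, on what has been measured and on what is new or still open speak of the compounds shown alone.

Working notes on the series.

Compound 1 `O=C(NCCC1CCN(Cc2ccccc2)CC1)c1coc2ccccc2c1=O` is the unsubstituted parent of the set. In an assay on isolated protein for inhibition of Amine oxidase [flavin-containing] A (Homo sapiens), read by fluorescence and Amplex Red, with stated times of 15 min and 20 min, tested at 100 uM (on this read-out lower numbers stand for less inhibition and higher numbers for more inhibition at the one concentration tested (going by the name of the read-out)), compound 1 gives 68.6%, the highest of the three numbers measured. Compound 2 `Cc1ccc2occ(C(=O)NCCC3CCN(Cc4ccccc4)CC3)c(=O)c2c1`, with methyl in place of hydrogen on an aromatic carbon, gives 30.6%, a step of a number 38 percentage points lower from compound 1 to compound 2 (beyond the scatter). Compound 3 `O=C(NCCC1CCN(Cc2ccccc2)CC1)c1coc2ccc(Br)cc2c1=O`, with bromo in place of hydrogen on an aromatic carbon, gives 48.2%, a step of a number 20.4 percentage points lower from compound 1 to compound 3 (beyond the scatter). Between the two substituted compounds the step is a number 17.6 percentage points higher from compound 2 to compound 3 (beyond the scatter).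

Compound 4 `COc1ccc2c(=O)c(C(=O)NCCC3CCN(Cc4ccccc4)CC3)coc2c1` differs from compound 1 by methoxy in place of hydrogen on an aromatic carbon. For the measured compounds named here, no measured step carries a methoxy group, and the two measured substitutions sit at other places on the shared core, so they bear on this change only loosely. Both show that adding a group to the aromatic ring of the core lowered the read-out beyond the scatter, by a large amount for methyl and a modest one for bromo. A step downward beyond the scatter is therefore expected for compound 4 as well, of a size between those two, estimated as a number 23.6 percentage points lower from compound 1 to compound 4 (beyond the scatter). The estimate for compound 4 in this assay is 45%, within a range from 22% to 68%.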

Compound 4, a percentage reported as inhibition, at one concentration (the size of the read-out at that concentration, not a potency): 32.4%
The estimate for compound 4 lay 12.6 percentage points above the measured number; low and high end bracket the measured number.
By their numbers in this assay, from the lowest: compounds 2 and 4 (each within the scatter of the next); then compound 3; then compound 1.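

Adding methoxy on an aromatic carbon of the shared core, meta to a fused ring and para to a fused ring, gives a number 36.2 percentage points lower from compound 1 to compound 4 (beyond the scatter) in this assay, so with methoxy at this place on the ring the number is lower by a large step. The step is large, like the one for methyl at another place, a number 38 percentage points lower from compound 1 to compound 2 (beyond the scatter), and unlike the modest one for bromo, a number 20.4 percentage points lower from compound 1 to compound 3 (beyond the scatter); all three substituted compounds therefore read lower than the unsubstituted compound 1, and none of the four goes against that pattern. No measurement shown accounts for the size of the step with methoxy.

Compound 4 is the only compound shown with a group at this place, so it remains open whether the fall belongs to methoxy itself or would follow any group placed there. A hydroxyl, an amine or a carboxylic acid at this place, or methoxy elsewhere on the same ring, would separate those two readings.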